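A few compounds are considered here, and "the series" means these few. Any claim that something is new, unique, unknown or untested is made for them only; others in the source may bear on it.

Compound 1, `Cc1cccc(NC(=O)CN2CCC(c3ccc(O)cc3)CC2)c1`: 70 nM
Compound 2, `Cc1ccc([N+](=O)[O-])cc1NC(=O)CN1CCC(c2cccc[n+]2[O-])CC1`: 134 nM
Compound 3, `O=C(CN1CCC(c2cccc[n+]2[O-])CC1)Nc1ccc(F)cc1F`: 103 nM

All three were tested in a functional assay on HEK293 cells for agonist activity at D(4) dopamine receptor (Homo sapiens), read by FLIPR; on this read-out higher numbers stand for an effect only at larger amounts of compound and lower numbers for an effect already at smaller amounts. On paper compound 1 has the lowest of the three numbers, but its gap to compound 3 and its gap to compound 2 both fall within the usual scatter of repeated measurements, so no ranking among the three can be claimed; the three simply look alike in this assay.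

The next compound, compound 4, `Cc1cccc(NC(=O)CN2CCC(c3ccccc3F)CC2)c1`, keeps the shared core of compound 1 and changes only the group on the saturated ring carbon:

2-fluorophenyl in place of 4-hydroxyphenyl on a saturated ring carbon

In words, the change swaps a group that can both give and take a hydrogen bond for one that does neither, leaving the rest of the molecule untouched. Going by the values given here, no measured pair among the three compounds shows this kind of change, so there is no direct precedent for its size. The measured set gives no hint that the group at this position is decisive, and the three values all sit close together. The expectation is therefore a modest move toward a higher number, a 2.6-fold higher number from compound 1 to compound 4 (0.41 log units; beyond the scatter), with wide uncertainty in either direction. Compound 4 is estimated at 180 nM, within a range from 50 nM to 700 nM.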

Compound 4, half-maximal effective concentration: 1 nM
Beside the measured number, compound 4's estimate is 180-fold (2.26 log units) above it; measured number outside the range, below it.
By their numbers in this assay, from the lowest: compound 4; then compounds 1, 3 and 2 (each within the scatter of the next).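

The three earlier compounds sat so close together that they gave no sign that the group on this saturated ring carbon matters, but in this assay this single change brings a 70-fold lower number from compound 1 to compound 4 (1.85 log units; beyond the scatter). The two groups have the same count of heavy atoms and each is one six-membered aromatic ring of carbon only, so the swap leaves both of those unchanged while removing the hydrogen-bond donor and acceptor counted on 4-hydroxyphenyl and bringing in a fluorine. No supporting data are available to say which part of this swap drives so large a step.

The swap alters both the substituent on the aromatic ring and its place on that ring, so the compounds shown cannot separate the two, and plain phenyl, 4-fluorophenyl or 2-hydroxyphenyl on the core of compound 1 would be the telling comparisons. From the compounds shown here alone, it also stays open whether 2-fluorophenyl would give a similarly low number alongside the other amide aromatic rings seen in compound 2 and compound 3.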